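Thiophene analogue: methoxy to ethoxy on the shared core

The source may report more compounds than this note shows. Statements on the series, on what has been measured and on what is new or still open speak of the compounds shown alone.

For the measured compounds named here, compound 3 `COc1nc(-c2cc3ccccc3o2)cc(-c2cccs2)c1C#N` gives 163000 nM in a functional assay on aorta (strain Wistar) for inhibition, with Thoracic aorta (Rattus norvegicus) as the target (a higher number here means a weaker inhibitor, a lower number a stronger inhibitor), and stands lowest of the three numbers so far. Going by the values given here, compound 1 `CCOc1nc(-c2cc3ccccc3o2)cc(-c2ccc3ccccc3c2)c1C#N` gives 423000 nM in this assay, and compound 2 `CCOc1nc(-c2cc3ccccc3o2)cc(-c2ccc(Cl)cc2Cl)c1C#N` gives 442000 nM; both lie beyond the scatter above compound 3, and the only measured single-point step, a 1.0-fold higher number from compound 1 to compound 2 (0.02 log units; within the scatter), concerns a swap of aryl groups and stays within the scatter.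

Compound 4 `CCOc1nc(-c2cc3ccccc3o2)cc(-c2cccs2)c1C#N` is not yet measured. It differs from compound 3 by methyl in place of hydrogen on a saturated chain carbon bound to an oxygen on an aromatic ring; read one bond further out, this is methoxy to ethoxy. Among the compounds with values here, compounds 1 and 2 carry the ethoxy group, but no measured pair differs from another only in this group, so no measured step bears on the change directly, and the aryl step from compound 1 to compound 2 gives no guidance on it either.

With nothing in the series speaking for a shift, a step of a 1.1-fold higher number from compound 3 to compound 4 (0.04 log units; within the scatter) is expected for compound 4, meaning no change beyond the scatter in this assay. Compound 4 is therefore estimated at 180000 nM in this assay, with a range of 70000 nM to 450000 nM.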

Compound 4, half-maximal inhibitory concentration: 308000 nM
Compound 4: the middle estimate sits 1.7-fold (0.23 log units) below what was measured; measured number inside the range.
By their numbers in this assay, from the lowest: compounds 3, 4, 1 and 2 (each within the scatter of the next, the first and the last beyond it).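

Methoxy to ethoxy, the methyl in place of hydrogen on a saturated chain carbon bound to an oxygen on an aromatic ring, now has a direct reading in this assay: a 1.9-fold higher number from compound 3 to compound 4 (0.28 log units; within the scatter) shows that this added methyl shifts the number by no more than the scatter on the thiophene analogue. With ethoxy held constant, thiophen-2-yl gives a 1.4-fold lower number from compound 2 to compound 4 (0.16 log units; within the scatter) against 2,4-dichlorophenyl and a 1.4-fold lower number from compound 1 to compound 4 (0.14 log units; within the scatter) against naphthalen-2-yl, so this aryl position, so far read only through a swap between two larger groups, does not separate the three groups named here. No measurement is at hand that could give a cause for any of these steps.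

As far as these compounds go, whether a longer chain such as propoxy, or an ethoxy chain ending in an amine or a carboxylic acid, would move the number beyond the scatter remains open. For the compounds shown here, also open is whether methoxy to ethoxy reads the same with naphthalen-2-yl or 2,4-dichlorophenyl in place of thiophen-2-yl, since the only pair that isolates this change carries thiophen-2-yl.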